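Notes on the side chain of compound 1

This account rests on a few compounds, and the source may have more. Where it says the series, first, only, none or still open, it means among the compounds named here.

Among the compounds with values here, compound 1 `CN(C)C(=O)c1cc2cnc(Nc3ccc(C(=O)NCCCN=C=S)cc3)nc2n1C1CCCC1` is the weaker of the two compounds measured so far: in a functional assay on A549 cells (Homo sapiens) for inhibition, read by CCK-8 assay, with a stated time of 72 h, tested at 1 uM (on this read-out higher numbers stand for a stronger effect at the one concentration tested and lower numbers for a weaker effect), compound 1 gives 32.9%, while compound 2 `CN(C)C(=O)c1cc2cnc(Nc3ccc(C(=O)NCCCN=C=S)cc3O)nc2n1C1CCCC1` gives 55.9%. Within the data shown here, the only measured step, a number 23 percentage points higher from compound 1 to compound 2 (beyond the scatter), concerns hydroxy in place of hydrogen on an aromatic carbon and leaves the rest of the molecule untouched.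

Compound 3 `CN(C)C(=O)c1cc2cnc(Nc3ccc(N=C=S)cc3)nc2n1C1CCCC1` departs from compound 1 elsewhere: a group of 3 heavy atoms (1 carbon, 1 nitrogen, 1 sulfur; no ring) in place of a group of 9 heavy atoms (5 carbon, 2 nitrogen, 1 oxygen, 1 sulfur; no ring), on an aromatic carbon. Among the measured compounds shown here, no measured pair shows what this exchange does, so the step to compound 2 gives no guidance here, in either direction. With a single precedent of a different kind, the expectation for compound 3 can only be anchored on the value of compound 1 itself, with a range wide enough to allow either a drop or a rise beyond the scatter.

For compound 3 the estimate in this assay is 33%, with a range of 8% to 62%. The expected change, a number 0.1 percentage points higher from compound 1 to compound 3 (within the scatter), is taken to lie within the scatter, though with little confidence.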

Compound 3, a percentage reported as inhibition, at one concentration (the size of the read-out at that concentration, not a potency): 44.4%
Compound 3: middle estimate off by 11.4 percentage points, on the low side; measured number inside the range.
By their numbers in this assay, from the lowest: compound 1; then compound 3; then compound 2.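

In this assay, the position on the aromatic carbon, para to a large group, tolerates a drastic shortening of the side chain: the group of 3 heavy atoms in place of the group of 9 heavy atoms gives a number 11.5 percentage points higher from compound 1 to compound 3 (beyond the scatter). The group of 9 heavy atoms, with its 1 hydrogen-bond donor, is therefore not required for the effect seen at the one concentration tested, and the shorter group, with 0 hydrogen-bond donors, gives the higher number of this pair. This adds a second place on compound 1 where a single change raises the read-out beyond the scatter, alongside the hydroxy exchange on the aromatic carbon, and nothing at hand bears on why the number moves at this position.

The compounds shown leave open how the read-out responds to chain lengths between the two groups, or to a longer chain, and whether an amine or a carboxylic acid in the same place keeps the effect. They also leave open whether the hydroxy group and the group of 3 heavy atoms combine on one molecule, and these single-concentration numbers say nothing about potency.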